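Chromone series: antiproliferative limits and an untested dienyl analogue

The source may report more compounds than this note shows. Statements on the series, on what has been measured and on what is new or still open speak of the compounds shown alone.

Measured so far:
compound 1 `CCCCCCCCCCCCCCCc1cc(=O)c2c(O)c(C)c(OCOC)cc2o1`: > 87000 nM
compound 2 `CCCCC/C=C\C/C=C\CCCCCCCc1cc(=O)c2c(O)c(C)c(OCOC)cc2o1`: > 87000 nM
compound 3 `CCCCCCCCCCCCCCCc1cc(=O)c2c(O)c(C)c(O)c(C)c2o1`: > 87000 nM

In a functional assay on MDA-MB-231 cells (Homo sapiens) for antiproliferative activity, read by MTT assay (a lower number here means a stronger inhibitor, a higher number a weaker inhibitor), compound 1 gives > 87000 nM, which is a limit of the assay and not a number. Compound 2 gives > 87000 nM, again a limit. Compound 3 gives > 87000 nM, also a limit. The change from compound 1 to compound 2 is deca-1,4-dien-1-yl in place of octyl on a saturated chain carbon, seven bonds along the chain from an aromatic carbon; the step it made in this assay is a step that the two limits leave unreadable from compound 1 to compound 2. Across the set, (the limit of > 87000 nM in this assay, at which 3 of the 3 values shown sit). The difference between the core of compound 1 and the core of compound 3 is not broken down here.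

Compound 4 `CCCCC/C=C\C/C=C\CCCCCCCc1cc(=O)c2c(O)c(C)c(O)c(C)c2o1` carries the same change made on compound 3: deca-1,4-dien-1-yl in place of octyl on a saturated chain carbon, seven bonds along the chain from an aromatic carbon. The place is the same word for word in both cases. The expected step is a step that the limit leaves unreadable from compound 3 to compound 4, resting on compound 3 at > 87000 nM and on the unreadable a step that the two limits leave unreadable from compound 1 to compound 2. Compound 4 is expected to give 100000 nM in this assay, most probably again only as a limit.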

Compound 4, half-maximal inhibitory concentration: 16100 nM
The estimate for compound 4 lay 6.2-fold (0.79 log units) above the measured number; the measured number lies below the stated range.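

In this assay, deca-1,4-dien-1-yl in place of octyl on the core of compound 3 gives an at least 5.4-fold lower number from compound 3 to compound 4 (0.73 log units; beyond the scatter). On the core of compound 1 the same change leads to compound 2, which gives > 87000 nM, a limit of the assay and not a number, and the step to it cannot be read. Whether the change carries from one core to the other is therefore neither shown nor excluded, and most of the set stays unresolved: the limit of > 87000 nM in this assay, at which 3 of the 4 values shown sit.

The change alters chain length and double bonds together, and the compounds shown do not separate the two. Going by these compounds, how a saturated decyl chain or a terminal carboxylic acid would read on the core of compound 3 remains open.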